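Pyridin-4-yl Gives Way to Methyl on a Shared Core

The compounds below may be only part of what the source reports. "The series", "measured", "known", "first", "only" and "open" are said of these compounds alone.

Of the compounds shown here, two built on one shared core have been tested in a functional assay on MDA-MB-231 cells (Homo sapiens) for cytotoxicity, read by MTT assay; on this read-out higher numbers stand for weaker inhibition and lower numbers for stronger inhibition. Compound 1 `c1ccc2c(-c3nnc(-c4ccncc4)o3)c[nH]c2c1` carries a pyridin-4-yl group on its five-membered ring. In this assay compound 1 gives > 1000000 nM, which is a limit of the assay and not a number. Compound 2 `COc1cc(-c2nnc(-c3c[nH]c4ccccc34)o2)ccc1O` is a close relative of compound 1 with a different aromatic group in place of the pyridin-4-yl. In this assay compound 2 likewise returns only a limit, > 1000000 nM. So compound 1 stands exactly where compound 2 stands, at the limit of > 1000000 nM in this assay, at which 2 of the 2 values shown sit, with no measurable cytotoxicity for either.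

Compound 3 `Cc1nnc(-c2c[nH]c3ccccc23)o1` has not yet been measured. It differs from compound 1 by methyl in place of pyridin-4-yl on an aromatic carbon. Among the compounds with values here, no measured pair shows this particular change, and both measured compounds sit at the limit, so there is no scale of activity from which to read a step. The expectation is therefore no step beyond the scatter, with the estimated change a number no higher from compound 1 to compound 3 (the limit leaves the size open). Compound 3 is expected to come in around 1000000 nM, in a range from 300000 nM to 3000000 nM, most likely reported again as a limit.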

Compound 3, half-maximal inhibitory concentration: > 1000000 nM
Compound 3: a limit, no number (the forecaster's own chance of this, stated with the estimate: 80%); the middle value lies on the limit itself.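

Compound 1 and compound 3 both return only a limit of the assay, not a number, in this assay, so no step can be read between them: the limit of > 1000000 nM in this assay, at which 3 of the 3 values shown sit.

The compounds shown leave open how methyl and pyridin-4-yl compare on a readable scale, and whether any group on the shared core gives a measurable value.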